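The source may hold more compounds than are shown below. What is called first, only, known or untested is meant among the compounds shown, and "the series" means these compounds.

Measured compounds in a functional assay on HepG2 cells (Homo sapiens) for cytotoxicity, read by MTT assay, with a stated time of 48 h; a lower number here means a stronger inhibitor, a higher number a weaker inhibitor:

Compound 1, `C#CCSc1nnc(CCC)n1N1C(=O)c2ccccc2C1=O`, gives a value that is only a limit of this assay, > 200000 nM.
Compound 2, `CCCc1nnc(SCc2ccccc2Cl)n1N1C(=O)c2ccccc2C1=O`, likewise gives only a limit, > 200000 nM.
Compound 3, `COc1cc(-c2nnc(SCc3ccccc3Cl)n2N2C(=O)c3ccccc3C2=O)cc(OC)c1OC`, also gives only a limit, > 200000 nM.

All three values sit at the same limit, (the limit of > 200000 nM in this assay, at which 3 of the 3 values shown sit), so neither step between measured compounds can be read. The change from compound 2 to compound 1 is ethynyl in place of 2-chlorophenyl on a saturated chain carbon bound to a sulfur, and its step, a step that the two limits leave unreadable from compound 2 to compound 1, stays unreadable. The cores of compound 2 and compound 3 differ by 3,4,5-trimethoxyphenyl in place of propyl on an aromatic carbon, with the step that the two limits leave unreadable from compound 2 to compound 3 equally unreadable.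

Compound 4, `C#CCSc1nnc(-c2cc(OC)c(OC)c(OC)c2)n1N1C(=O)c2ccccc2C1=O`, has not been measured. It carries the same change as compound 1 does against compound 2, namely (ethynyl in place of 2-chlorophenyl on a saturated chain carbon bound to a sulfur), with the place identical in both cases. Because every measured compound sits at the limit (the limit of > 200000 nM in this assay, at which 3 of the 3 values shown sit), the step from compound 3 to compound 4 is expected to be small, a step that the limit leaves unreadable from compound 3 to compound 4. Compound 4 is therefore estimated to return only a limit in this assay as well, around 250000 nM, between 80000 nM and 800000 nM.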

Compound 4, half-maximal inhibitory concentration: > 200000 nM
Compound 4: a limit, no number (the forecaster's own chance of this, stated with the estimate: 85%); the middle value lies beyond the limit too.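

Compound 3 and compound 4 both return only a limit, so the step between them cannot be read: the limit of > 200000 nM in this assay, at which 4 of the 4 values shown sit.

The compounds shown leave open which change to the shared core, if any, would give a number rather than a limit.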